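A few compounds are considered here, and "the series" means these few. Any claim that something is new, unique, unknown or untested is made for them only; others in the source may bear on it.

Measured so far:
- compound 1, `CCCC(=O)Nc1ccc(Oc2ccc(OC)cc2)cc1`: > 400 nM
- compound 2, `COc1cccc(Oc2ccc(NC(C)=O)cc2)c1`: 4.1 nM

Among the compounds with values here, in an assay on isolated protein for binding affinity to melatonin receptor type 1B (Homo sapiens) (on this read-out lower numbers stand for stronger inhibition and higher numbers for weaker inhibition), compound 2 gives 4.1 nM, the only number obtained in this set. For compound 1 the result is a limit of this assay, not a number: the limit of > 400 nM in this assay, at which 1 of the 2 values shown sits. Compounds 1 and 2 differ in more than one place, so the two results are simply set side by side, without a step between them.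

Compound 3, `C/C=C/C(=O)Nc1ccc(Oc2cccc(OC)c2)cc1`, has not yet been measured. Relative to compound 2 the change is prop-1-en-1-yl in place of methyl on a carbonyl carbon; the prop-1-en-1-yl group enters on the carbonyl carbon whose other neighbour is the amide-type nitrogen, so the acetamido becomes ((prop-1-en-1-yl)carbonyl)amino. Within the data shown here, no measured step covers that change, and compound 1, with its longer chain, carries a different arrangement of the methoxy group as well, so it does not set a direction.

The step from compound 2 to compound 3 is expected to be small, a 2.4-fold higher number from compound 2 to compound 3 (0.39 log units; beyond the scatter), a modest loss at most. Compound 3 is therefore estimated at 10 nM, within 2 nM to 60 nM.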

Compound 3, inhibition constant: 2.1 nM
Compound 3: the middle estimate sits 4.8-fold (0.68 log units) above what was measured, within the range that was stated.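

a 2.0-fold lower number from compound 2 to compound 3 (0.29 log units; within the scatter). Within the data shown here, this is the first one-place comparison, and it shows that the carbonyl carbon of the acetamido group accepts prop-1-en-1-yl in place of methyl, with 3 heavy atoms and a double bond outside aromatic rings entering where 1 heavy atom leaves, and that compound 2 and compound 3 cannot be told apart in this assay. Nothing at hand explains why the larger group leaves the read-out within the scatter.

In this assay compound 1 gives > 400 nM, which is a limit of the assay and not a number, and since compound 1 differs from compound 2 in more than one place, it cannot show whether its longer saturated chain or its arrangement of the methoxy group goes with that limit. Also open, going by these compounds, is how far this carbonyl carbon tolerates further change: a propyl chain paired with the methoxy arrangement of compound 2, a cyclopropyl ring or a longer chain such as pentyl could each separate from compound 2 or stay within the scatter.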